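From an allylamino quinone to an aziridinyl analogue

The source may report more compounds than this note shows. Statements on the series, on what has been measured and on what is new or still open speak of the compounds shown alone.

Measured so far:
compound 1, `C=CCNC1=CC(=O)c2nc(-c3ccccc3)ccc2C1=O`, 1910 nM
compound 2, `COc1cc(CNC2=CC(=O)c3nc(-c4ccccc4)ccc3C2=O)cc(OC)c1OC`, 2340 nM

Of the compounds shown here, two sharing one core have been tested in a functional assay on NCI60 cells (Homo sapiens) for cytotoxicity; on this read-out higher numbers stand for weaker inhibition of growth and lower numbers for stronger inhibition of growth. Compound 1 gives 1910 nM, the lower of the two numbers, and compound 2 gives 2340 nM; the two values lie within the scatter of each other, so neither can be called the stronger. Compound 3 `O=C1C(N2CC2)=CC(=O)c2nc(-c3ccccc3)ccc21` is not yet measured. It differs from compound 1 in one place: aziridin-1-yl in place of allylamino on a double-bonded ring carbon. Going by the values given here, no measured pair shows a change of this kind, so the size of the step is open. A step toward stronger growth inhibition is expected, a 2.1-fold lower number from compound 1 to compound 3 (0.33 log units; beyond the scatter). For compound 3 the estimate is 900 nM, within a range from 200 nM to 4000 nM.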

Compound 3, concentration for 50% growth inhibition: 27.5 nM
Compound 3: the middle estimate sits 33-fold (1.51 log units) above what was measured, and the stated range ends above it.
By their numbers in this assay, from the lowest: compound 3; then compounds 1 and 2 (each within the scatter of the next).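

On this double-bonded ring carbon, the choice of group can matter far more than compounds 1 and 2 could reveal. In this assay, aziridin-1-yl in place of allylamino brings a 69-fold lower number from compound 1 to compound 3 (1.84 log units; beyond the scatter) and thus a large move toward stronger growth inhibition. Nothing available explains the size of this step.

On these data alone, it remains open whether the three-membered ring is required or whether losing the hydrogen-bond donor of allylamino is enough. The compounds shown include no azetidin-1-yl or dimethylamino group on this carbon to separate these possibilities.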